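Solubility notes on the shared core: compound 2 to compound 4

The compounds below may be only part of what the source reports. "The series", "measured", "known", "first", "only" and "open" are said of these compounds alone.

The series is read in a physicochemical assay for solubility, read by LC-MS, in phosphate buffer, with a stated time of 24 h, at pH 7.4; a lower number here means a less soluble compound, a higher number a more soluble compound. Compound 1 `CN(c1ccn(C)n1)c1cnc(NCc2c(F)ccc3c2CCO3)c2cn[nH]c(=O)c12` gives 12000 nM. Compound 2 `O=C(Nc1cnc(NCc2c(F)ccc3c2CCO3)n2cnnc12)c1ccccc1` gives 2000 nM, the lowest of the two numbers measured; the nearest number is that of compound 1, a step beyond the scatter. Compound 3 `Cc1ncccc1-c1cnc(NCc2c(F)ccc3c2CCO3)n2c(=O)[nH]nc12` returns only a limit, < 2000 nM, so no number is known for it. That limit is the one (the limit of < 2000 nM in this assay, at which 1 of the 3 values shown sits).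

Compound 4 `CN(c1cccnc1)c1cnc(NCc2c(F)ccc3c2CCO3)n2cnnc12` has not yet been measured. It differs from compound 2 in one place: methyl(pyridin-3-yl)amino in place of benzamido on an aromatic carbon. For the measured compounds named here, no step between two measured compounds matches this change, so there is nothing to carry over directly. Going by the values given here, the two numbers known so far are that of compound 2, 2000 nM, and that of compound 1, 12000 nM, and the estimate for compound 4 is placed inside the span between them.

The step expected in this assay is a 2.3-fold higher number from compound 2 to compound 4 (0.35 log units; beyond the scatter), an increase that may or may not clear the usual scatter. Compound 4 is accordingly expected to show 4500 nM, with a range from 1500 nM to 14000 nM. A reading at the limit of the assay remains possible for compound 4.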

Compound 4, solubility: 47000 nM
Beside the measured number, compound 4's estimate is 10-fold (1.02 log units) below it; the whole stated range lies below it.
By their numbers in this assay, from the lowest: compound 2; then compound 1; then compound 4.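

In this assay, for the compounds shown here, this place on the shared core, on an aromatic carbon and para to a large group, gives the first readable step: a 24-fold higher number from compound 2 to compound 4 (1.37 log units; beyond the scatter), with methyl(pyridin-3-yl)amino in place of benzamido. Going by these compounds alone, the earlier compounds gave no step at all, so this is the first sign that the number can move strongly with the group at this place, and compound 4 now stands clear of compound 2. The exchange alters several things at once, from a ring of carbon only to a ring with 1 hetero atom, from 1 hydrogen-bond donor to 0, and with the double bond outside the aromatic rings gone, and nothing measured here assigns the step to any one of these.

The compounds shown leave open which part of the exchange goes with the step, since the ring and the link to the core change together; a methyl(phenyl)amino group or a pyridine-3-carbonylamino group at the same place would divide the two. Also open, as far as these compounds go, is whether a step of this size holds on other cores, as compound 1 and compound 3 do not differ from compound 2 or compound 4 in one place only.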